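Removing the Chloro from a Chalcone That Sits at the Limit

The compounds below may be only part of what the source reports. "The series", "measured", "known", "first", "only" and "open" are said of these compounds alone.

Compound 1 `Cc1ccc(Nc2nc(C)c(C(=O)/C=C/c3ccc(Cl)cc3)s2)cc1` was examined in a functional assay on NCI-H460 cells (Homo sapiens) for cytotoxicity, read by MTT assay; a higher number here means a weaker inhibitor, a lower number a stronger inhibitor. In this assay compound 1 gives > 25000 nM, which is a limit of the assay and not a number. Compound 2 `Cc1nc(Nc2ccc(Cl)cc2)sc1C(=O)/C=C/c1ccc(Cl)cc1` gives in this assay > 25000 nM, again only a limit. Compound 3 `Cc1nc(Nc2ccc(Cl)c(Cl)c2)sc1C(=O)/C=C/c1ccc(Cl)cc1` gives in this assay > 25000 nM, also a limit. The steps a step that the two limits leave unreadable from compound 1 to compound 2, a step that the two limits leave unreadable from compound 1 to compound 3 and a step that the two limits leave unreadable from compound 2 to compound 3 cannot be sized, since (the limit of > 25000 nM in this assay, at which 3 of the 3 values shown sit).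

Compound 4 `Cc1ccc(Nc2nc(C)c(C(=O)/C=C/c3ccccc3)s2)cc1` differs from compound 1 by hydrogen in place of chloro on an aromatic carbon. For the measured compounds named here, none of the measured steps touches this ring; all three move groups on the aryl attached to the nitrogen, so no measured step bears directly on the change from compound 1 to compound 4. With compound 1 resting at a limit, the step that the limit leaves unreadable from compound 1 to compound 4 is expected to leave compound 4 in the same region, with no readable direction. Compound 4 is therefore estimated at 40000 nM, within a range of 10000 nM to 200000 nM, most likely reported again as a limit.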

Compound 4, half-maximal inhibitory concentration: > 25000 nM
Compound 4 gave a limit, no number; the forecaster's own chance of this, stated with the estimate: 85%; the middle value lies beyond the limit too.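

In this assay compound 4 gives > 25000 nM, which is a limit of the assay and not a number. Compound 1 also rests at a limit, so no new step can be read between compound 1 and compound 4: the limit of > 25000 nM in this assay, at which 4 of the 4 values shown sit. The compounds shown leave open how strong any of the four is, and whether the chloro has any bearing on the cytotoxicity.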